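Carbonate to chloro on the chain of compound 1

The compounds below may be only part of what the source reports. "The series", "measured", "known", "first", "only" and "open" are said of these compounds alone.

Compound 1 `CCOC(=O)OCC#CCSc1c(SC)cnc2ccccc12` and compound 2 `CSc1cnc2ccccc2c1SCC#CCOC(=O)c1ccc(C(=O)O)cc1` share a core and a chain carrying a triple bond; they differ only in the group on a carbonyl carbon. In a functional assay on P388 cells (Mus musculus) for antiproliferative activity, with a stated time of 72 h (a higher number here means a weaker inhibitor, a lower number a stronger inhibitor), compound 1 gives 34.7 ug/mL and compound 2 gives 35 ug/mL. Of the two numbers, compound 1 holds the lower one, but the step of a 1.0-fold higher number from compound 1 to compound 2 (0.00 log units; within the scatter) shows that the two compounds cannot be told apart on this assay.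

Compound 3 `CSc1cnc2ccccc2c1SCC#CCCl` is not yet measured. It differs from compound 1 by chloro in place of (ethoxycarbonyl)oxy on a saturated chain carbon bound to a triple-bonded carbon. Among the measured compounds shown here, the only measured step, from compound 1 to compound 2, exchanged one group for another on a carbonyl carbon and left the number unchanged; nothing measured shows what happens when the whole (ethoxycarbonyl)oxy is removed and a chloro takes its place. That step bears only loosely on this change, so the expectation rests on the observation that a large exchange on the carbonyl carbon had no effect. For compound 3 the step of a 1.4-fold lower number from compound 1 to compound 3 (0.14 log units; within the scatter) is expected to stay within or near the scatter. Compound 3 is estimated at 25 ug/mL in this assay, with a range from 8 ug/mL to 80 ug/mL.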

Compound 3, concentration for 50% inhibition: 2.7 ug/mL
For compound 3 the middle estimate is 9.3-fold (0.97 log units) above the measured one; measured number below the stated range.
By their numbers in this assay, from the lowest: compound 3; then compounds 1 and 2 (each within the scatter of the next).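

In this assay the saturated chain carbon bound to a triple-bonded carbon is a place where the number responds, with a 13-fold lower number from compound 1 to compound 3 (1.11 log units; beyond the scatter) on putting chloro in place of (ethoxycarbonyl)oxy. The earlier pair changed only the group on a carbonyl carbon, and a 1.0-fold higher number from compound 1 to compound 2 (0.00 log units; within the scatter) gave no separation, so that flat result does not carry over to replacing the whole carbonyl-bearing group on the chain. No measurement on hand accounts for the lower number of compound 3.

The compounds shown leave open whether the gain belongs to chloro itself or simply to the loss of the (ethoxycarbonyl)oxy group, a question that a bromo, a hydroxy or an amine on the same chain carbon would help to settle. They also leave open whether chloro gives a similar number on a longer chain, and whether the low number of compound 3 reflects anything beyond antiproliferative activity on this one cell line.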